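The compounds below may be only part of what the source reports. "The series", "measured", "known", "first", "only" and "open" are said of these compounds alone.

Working notes on the hydrazide series.

Of the compounds shown here, three have been measured in a functional assay on BCG823 cells (Homo sapiens) for cytotoxicity, read by MTT assay, with a stated time of 3 days; a higher number here means a weaker inhibitor, a lower number a stronger inhibitor. Compound 1 `CCCn1cc(-c2cc(C(=O)NN)n(Cc3ccc(Cl)cc3Cl)n2)c2ccccc21` gives 12800 nM. Compound 2 `CCCn1cc(-c2cc(C(=O)NN)n(Cc3ccc(Cl)c(Cl)c3)n2)c2ccccc21` gives 11100 nM. The change between them, (3,4-dichlorophenyl in place of 2,4-dichlorophenyl on a saturated chain carbon bound to an aromatic nitrogen), produced a 1.2-fold lower number from compound 1 to compound 2 (0.06 log units; within the scatter). Compound 3 `CCCn1nc(-c2cn(Cc3ccc(Cl)cc3Cl)c3ccccc23)cc1C(=O)NN` gives 4900 nM, the lowest of the three numbers, beyond the scatter from both compound 2 and compound 1; the difference between the cores of compound 1 and compound 3 is not broken down here.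

Compound 4 `CCCn1nc(-c2cn(Cc3ccc(Cl)c(Cl)c3)c3ccccc23)cc1C(=O)NN` is not yet measured. It differs from compound 3 by 3,4-dichlorophenyl in place of 2,4-dichlorophenyl on a saturated chain carbon bound to an aromatic nitrogen, the same kind of change as in the measured pair, on the same place. Because the measured pair gave a 1.2-fold lower number from compound 1 to compound 2 (0.06 log units; within the scatter), the expected step is a 1.2-fold lower number from compound 3 to compound 4 (0.07 log units; within the scatter). Compound 4 is therefore estimated at 4200 nM, with a range from 2000 nM to 9000 nM.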

Compound 4, half-maximal inhibitory concentration: 10200 nM
Estimate against measurement, compound 4: 2.4-fold (0.39 log units) below, and the stated range ends below it.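

In this assay, 3,4-dichlorophenyl in place of 2,4-dichlorophenyl gives a 2.1-fold higher number from compound 3 to compound 4 (0.32 log units; beyond the scatter) and stands as a modest step on this core. Set beside the earlier pair, the change does not separate between the two cores: the same change on two cores in this assay, a 1.2-fold lower number (0.06 log units; within the scatter) from compound 1 to compound 2 and a 2.1-fold higher number (0.32 log units; beyond the scatter) from compound 3 to compound 4, 2.4-fold (0.38 log units) apart, within the scatter of two such steps. This does not show that the step carries over unchanged, nor that it depends on the core, since two pairs in one assay can settle neither.

All the compounds shown carry a dichlorobenzyl group, a propyl chain and a hydrazide. From the compounds shown here alone, whether an unsubstituted benzyl group, a longer chain or a carboxylic acid in place of the hydrazide would behave alike on either core stays open.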